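Naphthalenyl for formylphenyl: a second test of one step

The compounds below may be only part of what the source reports. "The series", "measured", "known", "first", "only" and "open" are said of these compounds alone.

Measured so far in a functional assay on UACC-62 cells (Homo sapiens) for inhibition, read by sulforhodamine B assay, with a stated time of 48 h, tested at 10 uM; a higher number here means more inhibition at the concentration tested (going by the name of the read-out), a lower number less inhibition:
compound 1, `O=Cc1ccc(-c2cn3ccnc3c(-c3ccc4ncn(C5CCCCC5)c4c3)n2)cc1`, 37.1%
compound 2, `c1ccc2c(-c3cn4ccnc4c(-c4ccc5ncn(C6CCCCC6)c5c4)n3)cccc2c1`, 16.7%
compound 3, `O=Cc1ccc(-c2cn3ccnc3c(-c3ccc4ncn(Cc5ccccc5)c4c3)n2)cc1`, 37.1%

Of the compounds shown here, three have been measured, and a fourth, compound 4, `c1ccc(Cn2cnc3ccc(-c4nc(-c5cccc6ccccc56)cn5ccnc45)cc32)cc1`, has not. Compound 1 and compound 3 share one core apart from a single group on an aromatic nitrogen; that difference is benzyl in place of cyclohexyl on an aromatic nitrogen, and it makes no change at the digits printed from compound 1 to compound 3 (within the scatter). Compound 3 therefore stands level with compound 1, and the two together give the highest numbers of the three.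

The change from compound 1 to compound 2 is naphthalen-1-yl in place of 4-formylphenyl on an aromatic carbon, and it makes a number 20.4 percentage points lower from compound 1 to compound 2 (beyond the scatter). The change from compound 3 to compound 4 is naphthalen-1-yl in place of 4-formylphenyl on an aromatic carbon. It occurs twice among the compounds shown, and the two place descriptions agree word for word, so it is the same change carried out on the core of compound 3 rather than on the core of compound 1.

Within the data shown here, because the only measured instance of this change gives a number 20.4 percentage points lower from compound 1 to compound 2 (beyond the scatter), and because compound 3 starts from 37.1%, compound 4 is expected to fall by a similar amount, a number 20.1 percentage points lower from compound 3 to compound 4 (beyond the scatter). For compound 4 the estimated value in this assay is 17%, with a range expected from 5% to 32%.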

Compound 4, a percentage reported as inhibition, at one concentration (the size of the read-out at that concentration, not a potency): 12.9%
For compound 4 the middle estimate is 4.1 percentage points above the measured one; the range from low to high includes it.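

In this assay, among these compounds, naphthalen-1-yl in place of 4-formylphenyl on an aromatic carbon gives a number 24.2 percentage points lower from compound 3 to compound 4 (beyond the scatter), and set beside the earlier step, the change carries over from the core with cyclohexyl to the core with benzyl: the same change on two cores in this assay, a number 20.4 percentage points lower (beyond the scatter) from compound 1 to compound 2 and a number 24.2 percentage points lower (beyond the scatter) from compound 3 to compound 4, 3.8 percentage points apart, within the scatter of two such steps The other change, benzyl in place of cyclohexyl on an aromatic nitrogen, gives a number 3.8 percentage points lower from compound 2 to compound 4 (within the scatter) with naphthalen-1-yl in place, and it also reads alike in both settings: the same change on two cores in this assay, no change at the digits printed (within the scatter) from compound 1 to compound 3 and a number 3.8 percentage points lower (within the scatter) from compound 2 to compound 4, 3.8 percentage points apart, within the scatter of two such steps This agreement rests on only two pairs of compounds whose cores differ by a single group, with each compound read at one concentration in this assay, so it does not show that the step would hold on a more distant core, and it cannot separate the loss of the carbonyl from the gain of a second aromatic ring.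

The compounds shown leave open how a plain phenyl, or a phenyl carrying a carboxylic acid or an amine instead of the formyl group, would read on either core. They also leave open whether a longer chain on the aromatic nitrogen would keep the step from 4-formylphenyl to naphthalen-1-yl the same.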